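From piperazin-1-yl to methoxy: compound 3 and compound 4

The source may report more compounds than this note shows. Statements on the series, on what has been measured and on what is new or still open speak of the compounds shown alone.

Measured so far in an ADME assay on HepG2 cells (Homo sapiens) for cytotoxicity; a lower number here means that less compound is tolerated, a higher number that more compound is tolerated:
- compound 1 `CCOC(=O)CN(C)CC#Cc1cc2ncnc(Nc3ccc(OCc4cccc(F)c4)c(Cl)c3)c2s1`: 26 uM
- compound 2 `CC(C)(C)CC#Cc1cc2ncnc(Nc3ccc(OCc4cccc(F)c4)c(Cl)c3)c2s1`: 29.3 uM
- compound 3 `Fc1cccc(COc2ccc(Nc3ncnc4cc(C#CCN5CCNCC5)sc34)cc2Cl)c1`: > 29 uM (a limit, not a number)

In this assay compound 3 has no exact number, and its > 29 uM is only a limit. Compound 4 `COCC#Cc1cc2ncnc(Nc3ccc(OCc4cccc(F)c4)c(Cl)c3)c2s1` differs from it in one place: methoxy in place of piperazin-1-yl on a saturated chain carbon bound to a triple-bonded carbon. In words, this puts methoxy in place of piperazin-1-yl on a saturated chain carbon bound to a triple-bonded carbon.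

Three measured steps change the group at this same place. The first is a 1.1-fold higher number from compound 1 to compound 2 (0.05 log units; within the scatter), the second is an at least 1.1-fold higher number from compound 1 to compound 3 (0.04 log units; that floor lies within the scatter), and the third is a step that the limit leaves unreadable from compound 2 to compound 3. Among these three compounds, no readable step at this place goes beyond the scatter, so none beyond the scatter is expected here either. The expected step is an at least 1.0-fold lower number from compound 3 to compound 4 (0.01 log units; that floor lies within the scatter). The estimate for compound 4 is 28 uM, with an expected range from 15 uM to 50 uM.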

Compound 4, half-maximal toxic concentration: > 33 uM
Compound 4: a limit, no number; the forecaster's own chance of this, stated with the estimate: 30%; middle value at least 1.1-fold (0.07 log units) from the limit.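

Methoxy brings only 2 heavy atoms and no ring to this place on a saturated chain carbon bound to a triple-bonded carbon, and in this assay compound 4 gives > 33 uM, which is a limit and not a number. Set against the two exact values, this reads as an at least 1.1-fold higher number from compound 2 to compound 4 (0.05 log units; that floor lies within the scatter) and as an at least 1.2-fold higher number from compound 1 to compound 4 (0.10 log units; that floor lies within the scatter), so even this small group shows no step beyond the scatter. The step between piperazin-1-yl and methoxy cannot be read, because both values are limits: the limit of > 33 uM in this assay, at which 1 of the 4 values shown sits.

From the compounds shown here alone, how far compound 3 and compound 4 actually lie past their limits stays open. Also open, going by these compounds, is whether a carboxylic acid or a longer carbon chain at this place would give a step beyond the scatter.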